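Swapping the Ring-Nitrogen Substituent on a Compound Whose Inhibition Is Low

A few compounds are considered here, and "the series" means these few. Any claim that something is new, unique, unknown or untested is made for them only; others in the source may bear on it.

Of the compounds shown here, three built on a shared core have been tested in a functional assay on NCI-H1975 cells (Homo sapiens) for inhibition, read by sulforhodamine B assay, tested at 10 uM; on this read-out lower numbers stand for less inhibition and higher numbers for more inhibition at the one concentration tested (going by the name of the read-out). Compound 1 `CN1CCN(c2ccc(C3=NN(C(=O)c4ccc(F)cc4)C(c4ccc(N(C)C)cc4)C3)cc2)CC1` gives 32.2% in this assay. Compound 2 `CN1CCN(c2ccc(C3=NN(S(C)(=O)=O)C(c4ccc(N(C)C)cc4)C3)cc2)CC1` gives -1.3%, and compound 3 `CN(C)c1ccc(C2CC(c3ccc(-n4cncn4)cc3)=NN2C(=O)c2ccc(F)cc2)cc1` gives -1.1%. Compound 3 thus stands second highest of the three numbers, within the scatter of compound 2, whereas the step of a number 33.3 percentage points lower from compound 1 to compound 3 (beyond the scatter) lies beyond it.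

Compound 4 `CN(C)c1ccc(C2CC(c3ccc(-n4cncn4)cc3)=NN2S(C)(=O)=O)cc1` has not yet been measured. It differs from compound 3 by methylsulfonyl in place of (4-fluorophenyl)carbonyl on an amine nitrogen in a ring. The same exchange occurs once among the measured compounds, in a number 33.5 percentage points lower from compound 1 to compound 2 (beyond the scatter), a large loss. That step, however, began from a compound showing clear inhibition, while compound 3 already shows essentially none, so a further fall of that size has little room. The expected step is therefore one that stays within the scatter, a number 1.9 percentage points lower from compound 3 to compound 4 (within the scatter). Compound 4 is expected to give about -3% in this assay, within a range from -15% to 10%.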

Compound 4, a percentage reported as inhibition, at one concentration (the size of the read-out at that concentration, not a potency): -3.1%
Compound 4: middle estimate off by 0.1 percentage points, on the high side; the range from low to high includes it.
By their numbers in this assay, from the lowest: compounds 4, 2 and 3 (each within the scatter of the next); then compound 1.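

In this assay, the exchange of (4-fluorophenyl)carbonyl for methylsulfonyl on the amine nitrogen in the ring has no fixed size: with 1H-1,2,4-triazol-1-yl on the aromatic carbon it gives a number 2 percentage points lower from compound 3 to compound 4 (within the scatter), and the two cases differ: the same change on two cores in this assay, a number 33.5 percentage points lower (beyond the scatter) from compound 1 to compound 2 and a number 2 percentage points lower (within the scatter) from compound 3 to compound 4, 31.5 percentage points apart, beyond the scatter of two such steps The reverse reading holds for the aromatic carbon, where 1H-1,2,4-triazol-1-yl in place of 4-methylpiperazin-1-yl gives a number 1.8 percentage points lower from compound 2 to compound 4 (within the scatter) once methylsulfonyl sits on the ring nitrogen, and again the two cases differ: the same change on two cores in this assay, a number 33.3 percentage points lower (beyond the scatter) from compound 1 to compound 3 and a number 1.8 percentage points lower (within the scatter) from compound 2 to compound 4, 31.5 percentage points apart, beyond the scatter of two such steps The two places therefore do not act independently here: the inhibition of compound 1 needs 4-methylpiperazin-1-yl and (4-fluorophenyl)carbonyl together, and either single exchange leaves a number near zero.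

Going by these compounds, it remains open whether morpholin-4-yl on the aromatic carbon would keep that inhibition. The same holds for an acetyl group or an unsubstituted benzoyl group on the ring nitrogen.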